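A few compounds are considered here, and "the series" means these few. Any claim that something is new, unique, unknown or untested is made for them only; others in the source may bear on it.

In an assay on HEK293 cells for displacement of a labelled ligand from 5-hydroxytryptamine receptor 4 (Homo sapiens), read by scintillation counting (a higher number here means a weaker inhibitor, a lower number a stronger inhibitor), compound 1 `COc1cc(N)c(Cl)cc1C(=O)NC1CCNCC1` gives 1580 nM and compound 2 `CCN1CCC(NC(=O)c2cc(Cl)c(N)cc2OC)CC1` gives 1000 nM; these two lie within the scatter of each other. Compound 3 `COc1cc(N)c(Cl)cc1C(=O)NC1CCN(CCCCCCCCO)CC1` gives 79.4 nM, the lowest of the three numbers: a 20-fold lower number from compound 1 to compound 3 (1.30 log units; beyond the scatter) and a 13-fold lower number from compound 2 to compound 3 (1.10 log units; beyond the scatter). Compound 4 `COc1cc(N)c(Cl)cc1C(=O)NC1CCN(CCCCCCCCN2CCCCC2)CC1` differs from compound 3 in one group: piperidin-1-yl in place of hydroxy on a saturated chain carbon, eight bonds along the chain from an amine nitrogen in a ring. Among the measured compounds shown here, both large measured steps came from putting a chain on the amine nitrogen in the ring, which compound 4 keeps; no measured step exchanges the group at the end of that chain, so there is nothing to set a direction. The step from compound 3 to compound 4 in this assay is therefore expected to be modest, a 1.6-fold lower number from compound 3 to compound 4 (0.20 log units; within the scatter), with either direction possible. Compound 4 is estimated at 50 nM, within 12 nM to 200 nM.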

Compound 4, inhibition constant: 3.16 nM
Beside the measured number, compound 4's estimate is 16-fold (1.20 log units) above it, and the stated range ends above it.
By their numbers in this assay, from the lowest: compound 4; then compound 3; then compounds 2 and 1 (each within the scatter of the next).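

The group at the far end of the chain matters as well as the chain itself: piperidin-1-yl in place of hydroxy, eight bonds along the chain from an amine nitrogen in a ring, gives a 25-fold lower number from compound 3 to compound 4 (1.40 log units; beyond the scatter), a large step. The number therefore still moves well beyond the scatter when only the chain end changes. Nothing available explains this gain.

Open, as far as these compounds go, is whether the ring is needed, since a diethylamino group or a carboxylic acid at the chain end would test this. Also open, from the compounds shown here alone, is how a shorter or longer chain carrying piperidin-1-yl would behave.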